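From Carboxymethoxy to Methoxy at a Cytotoxicity Limit

The source may hold more compounds than are shown below. What is called first, only, known or untested is meant among the compounds shown, and "the series" means these compounds.

Compound 1 `O=C(O)COc1cc(Cl)c(C(=O)Nc2cccc(-c3nc4ccccc4s3)c2)cc1[N+](=O)[O-]`: > 25000 nM
Compound 2 `Cc1cc(NC(=O)c2cc([N+](=O)[O-])ccc2Cl)cc(-c2nc3ccccc3o2)c1O`: > 25000 nM
Compound 3 `O=C(Nc1nc(-c2ccc(Cl)cc2)cs1)c1cc([N+](=O)[O-])ccc1Cl`: 18000 nM

In an ADME assay on BJ cells (Homo sapiens) for cytotoxicity, with a stated time of 72 h (on this read-out lower numbers stand for an effect already at smaller amounts and higher numbers for an effect only at larger amounts of compound), compound 1 gives > 25000 nM, which is a limit of the assay and not a number. It therefore stands at the limit of > 25000 nM in this assay, at which 2 of the 3 values shown sit. Compound 4 `COc1cc(Cl)c(C(=O)Nc2cccc(-c3nc4ccccc4s3)c2)cc1[N+](=O)[O-]` has not yet been measured. It differs from compound 1 in one place: hydrogen in place of carboxy on a saturated chain carbon bound to an oxygen on an aromatic ring. This is hydrogen in place of carboxy on a saturated chain carbon bound to an oxygen on an aromatic ring, so carboxymethoxy becomes methoxy.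

For the measured compounds named here, no measured pair shows this change directly. The expectation rests on compound 3, which carries no carboxy and gives 18000 nM. Compound 2 goes against this reading: it also lacks carboxy and gives > 25000 nM, a limit. In this assay, a small step toward lower numbers is therefore expected, or none beyond the scatter. The expected change is an at least 1.2-fold lower number from compound 1 to compound 4 (0.09 log units; that floor lies within the scatter). For compound 4 the estimated value is 20000 nM, with an expected range from 9000 nM to 35000 nM.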

Compound 4, half-maximal effective concentration: > 25000 nM
Compound 4: no number, only a limit; the forecaster's own chance of this, stated with the estimate: 55%; at least 1.2-fold (0.09 log units) between middle value and limit.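

In this assay compound 4 gives > 25000 nM, which is a limit of the assay and not a number. Compound 1 also stands at a limit, so no step can be read from compound 1 to compound 4. The compounds shown leave open whether replacing carboxymethoxy with methoxy changes this read-out at all.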